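The compounds below may be only part of what the source reports. "The series", "measured", "known", "first", "only" and "open" are said of these compounds alone.

Three compounds share one core and differ only in the ring that hangs from the amine. Compound 3 `N#Cc1c(Nc2cccc(Cl)c2)nc(SCc2cn(Cc3ccccc3Cl)nn2)nc1-c1ccccc1` gives 12000 nM in a functional assay on MCF7 cells (Homo sapiens) for inhibition, read by MTT assay, with a stated time of 72 h (on this read-out higher numbers stand for weaker inhibition and lower numbers for stronger inhibition), the highest of the three numbers, yet every step to it stays within the scatter. Compound 1 `COc1ccc(Nc2nc(SCc3cn(Cc4ccccc4Cl)nn3)nc(-c3ccccc3)c2C#N)cc1` gives 8050 nM in this assay, and compound 2 `N#Cc1c(Nc2ccc(Cl)cc2)nc(SCc2cn(Cc3ccccc3Cl)nn2)nc1-c1ccccc1` gives 6520 nM. The measured steps are a 1.2-fold lower number from compound 1 to compound 2 (0.09 log units; within the scatter), a 1.5-fold higher number from compound 1 to compound 3 (0.17 log units; within the scatter) and a 1.8-fold higher number from compound 2 to compound 3 (0.26 log units; within the scatter). Compound 4 `N#Cc1c(Nc2cccc([N+](=O)[O-])c2)nc(SCc2cn(Cc3ccccc3Cl)nn2)nc1-c1ccccc1` differs from compound 3 by nitro in place of chloro on an aromatic carbon. Among the compounds with values here, no measured step swaps chloro for nitro, so those three steps bear only indirectly: each change on this ring has moved this assay within the scatter. Compound 4 is therefore expected to show no change at the digits printed from compound 3 to compound 4 (within the scatter), nothing beyond the scatter. The estimate for compound 4 is 12000 nM, ranging from 5000 nM to 30000 nM.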

Compound 4, half-maximal inhibitory concentration: > 64000 nM
Compound 4: no number, only a limit; the forecaster's own chance of this, stated with the estimate: 10%; middle value at least 5.3-fold (0.72 log units) from the limit.
By their numbers in this assay, from the lowest: compounds 2, 1 and 3 (each within the scatter of the next). At a limit, above all of these: compound 4.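

In this assay compound 4 gives only a limit, > 64000 nM, and not a number. Nitro in place of chloro gives an at least 5.3-fold higher number from compound 3 to compound 4 (0.72 log units; beyond the scatter), and the other two steps, an at least 9.8-fold higher number from compound 2 to compound 4 (0.99 log units; beyond the scatter) and an at least 7.9-fold higher number from compound 1 to compound 4 (0.90 log units; beyond the scatter), also lie beyond the scatter. So the ring on the amine is not indifferent to what it carries, as the earlier changes, all within the scatter, had suggested. From the compounds shown here alone, how far past its limit compound 4 lies stays open. So does whether an amine or a carboxylic acid on this same ring carbon would move the number as nitro does.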